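The source may hold more compounds than are shown below. What is called first, only, known or untested is meant among the compounds shown, and "the series" means these compounds.

Working notes on the series. Among the measured compounds shown here, in a physicochemical assay for lipophilicity, read by HPLC, at pH 7.5 (a higher number here means a more lipophilic compound, a lower number a more polar compound), compound 1 (`CC[C@@H](Nc1c(C#N)c(-c2ccc(-c3cccc(C)c3)cc2)nc2cnccc12)C(N)=O`) gives 3, the highest of the three numbers so far. Compound 2 (`CCOc1ccccc1-c1ccc(-c2nc3cnccc3c(C[C@H](C)C(=O)O)c2C#N)cc1`) gives 2.2, and compound 3 (`CCOc1ccccc1-c1ccc(-c2nc3cnccc3c(N[C@H](CC)C(=O)NS(=O)(=O)C3CC3)c2C#N)cc1`) gives 2.3. Each of these two lies lower than compound 1 by more than the usual scatter. For the measured compounds named here, neither differs from compound 1 in one place only, so the measured set offers no direct step to lean on.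

Next in line is compound 4 (`CC[C@@H](Nc1c(C#N)c(-c2ccc(-c3ccc(OC)cc3)cc2)nc2cnccc12)C(N)=O`), which keeps the rest of compound 1 and changes one group: 4-methoxyphenyl in place of 3-methylphenyl on an aromatic carbon. This puts 4-methoxyphenyl in place of 3-methylphenyl on an aromatic carbon, para to a large group. Going by the values given here, with no measured precedent for this swap, the expectation rests on the structural change alone and is held loosely. The estimated step of a number 0.20 log units lower from compound 1 to compound 4 (within the scatter) is expected to be small and downward, and it may well stay within the scatter. For compound 4 the expected value in this assay is 2.8, with an estimated range from 2.4 to 3.2.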

Compound 4, distribution coefficient: 2.7
The estimate for compound 4 lay 0.10 log units above the measured number; measured number inside the range.
By their numbers in this assay, from the lowest: compounds 2 and 3 (each within the scatter of the next); then compounds 4 and 1 (each within the scatter of the next).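

Among the compounds shown here, putting 4-methoxyphenyl in place of 3-methylphenyl on an aromatic carbon, para to a large group, gives the first single-place step in this assay for this series, a number 0.30 log units lower from compound 1 to compound 4 (within the scatter). At this position, then, a group carrying an oxygen and a hydrogen-bond acceptor leaves the number within the scatter, something compounds 2 and 3 could not show, as neither differs from compound 1 in one place only. No supporting measurement bears on this result.

This one step changes both the substituent and where it sits on the ring, so the compounds shown cannot separate the two. Going by these compounds, how a hydroxyl group or a dimethylamino group in place of the methoxy group would read in this assay remains open.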